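Piperidine in Place of Morpholine: an Expected Gain in Potency

The source may hold more compounds than are shown below. What is called first, only, known or untested is meant among the compounds shown, and "the series" means these compounds.

Compound 1 `O=c1c(CSC(=S)N2CCCCC2)coc2cc(Cl)ccc12`: 380 nM
Compound 2 `O=c1c(CSC(=S)N2CCOCC2)coc2cc(Cl)ccc12`: 8100 nM
Compound 3 `O=c1c(CSC(=S)N2CCOCC2)coc2ccccc12`: 4000 nM

These three compounds share one core and were tested in a functional assay on MCF7 cells (Homo sapiens) for antiproliferative activity, read by MTT assay, with a stated time of 72 h; a lower number here means a stronger inhibitor, a higher number a weaker inhibitor. Compound 3 gives the second highest number of the three. Its nearest number belongs to compound 2, and that step was a 2.0-fold lower number from compound 2 to compound 3 (0.31 log units; beyond the scatter), a modest one. Compound 1 stands much lower than both.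

Compound 4 `O=c1c(CSC(=S)N2CCCCC2)coc2ccccc12` differs from compound 3 in one place: piperidin-1-yl in place of morpholin-4-yl on a thiocarbonyl carbon. For the measured compounds named here, the only measured step with this same change, run the other way, was a 21-fold higher number from compound 1 to compound 2 (1.33 log units; beyond the scatter), a large effect. The step to compound 4 is therefore expected to be large and downward: a 21-fold lower number from compound 3 to compound 4 (1.32 log units; beyond the scatter). Compound 4 is estimated at 190 nM, with a range from 80 nM to 500 nM.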

Compound 4, half-maximal inhibitory concentration: 1700 nM
For compound 4 the middle estimate is 8.9-fold (0.95 log units) below the measured one; measured number outside the range, above it.
By their numbers in this assay, from the lowest: compound 1; then compound 4; then compound 3; then compound 2.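

In this assay, piperidin-1-yl still gives the lower number without the chloro group, a 2.4-fold lower number from compound 3 to compound 4 (0.37 log units; beyond the scatter), but the size of this change depends on the core: the same change on two cores in this assay, a 21-fold higher number (1.33 log units; beyond the scatter) from compound 1 to compound 2 and a 2.4-fold higher number (0.37 log units; beyond the scatter) from compound 4 to compound 3, 9.1-fold (0.96 log units) apart, beyond the scatter of two such steps

Removing the chloro group also has opposite outcomes, raising the number on the piperidin-1-yl compounds, a 4.5-fold higher number from compound 1 to compound 4 (0.65 log units; beyond the scatter), while lowering it on the morpholin-4-yl pair: the same change on two cores in this assay, a 2.0-fold lower number (0.31 log units; beyond the scatter) from compound 2 to compound 3 and a 4.5-fold higher number (0.65 log units; beyond the scatter) from compound 1 to compound 4, 9.1-fold (0.96 log units) apart, beyond the scatter of two such steps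

The two changes therefore do not act independently across these four compounds.

Still open, from the compounds shown here alone, is whether an open-chain diethylamino group or a piperazine on the thiocarbonyl carbon would follow piperidin-1-yl or morpholin-4-yl. Going by these compounds, whether fluoro or methoxy in place of chloro would show the same dependence also remains unknown.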